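From a methoxypropyl to a branched alkyl chain

The source may hold more compounds than are shown below. What is called first, only, known or untested is meant among the compounds shown, and "the series" means these compounds.

Compound 1 `CCCOCCn1c(N2CCN(C)CC2)nc2ccccc21` gives 20 nM in a functional assay on ileum for inhibition of histamine H1 receptor (Cavia porcellus); a lower number here means a stronger inhibitor, a higher number a weaker inhibitor.
Compound 2 `CCCn1c(N2CCN(C)CC2)nc2ccccc21` gives 380 nM in this assay.
Compound 3 `COCCCn1c(N2CCN(C)CC2)nc2ccccc21` gives 860 nM in this assay.

Of the three measured compounds, compound 3 has the highest number in this assay: its nearest neighbour is compound 2, and the gap to compound 1 is far larger, as the step of a 43-fold higher number from compound 1 to compound 3 (1.63 log units; beyond the scatter) shows. Compound 4 `CCCC(C)Cn1c(N2CCN(C)CC2)nc2ccccc21` shares the core and differs from compound 3 only in the chain on the nitrogen: 1-methylbutyl in place of 2-methoxyethyl on a saturated chain carbon bound to an aromatic nitrogen.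

For the measured compounds named here, two measured steps bear on this change. The step of a 2.3-fold higher number from compound 2 to compound 3 (0.35 log units; beyond the scatter) shows that putting a methoxy onto the propyl chain raises the number modestly, so taking the oxygen out of the chain, as in compound 4, would be expected to move the number the other way by a similar amount. The step of a 19-fold higher number from compound 1 to compound 2 (1.28 log units; beyond the scatter) shows that a longer chain carrying an oxygen gives a much lower number than the short methyl, but compound 4 carries no oxygen, so that step is only a loose guide to its greater length. The expectation is therefore a moderate drop, a 3.4-fold lower number from compound 3 to compound 4 (0.54 log units; beyond the scatter), and compound 4 is estimated at 250 nM, within a range from 60 nM to 1000 nM.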

Compound 4, half-maximal inhibitory concentration: 500 nM
The estimate for compound 4 lay 2.0-fold (0.30 log units) below the measured number, and the stated range covers the measured number.
By their numbers in this assay, from the lowest: compound 1; then compounds 2, 4 and 3 (each within the scatter of the next, the first and the last beyond it).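

In this assay, replacing 2-methoxyethyl with 1-methylbutyl gives a step that cannot be told from the scatter (a 1.7-fold lower number from compound 3 to compound 4 (0.24 log units; within the scatter)), and the step from the shorter propyl chain is also within it (a 1.3-fold higher number from compound 2 to compound 4 (0.12 log units; within the scatter)), so this longer, branched all-carbon chain does not separate compound 4 from either compound. The one large gap that remains is to the propoxy chain (a 25-fold higher number from compound 1 to compound 4 (1.40 log units; beyond the scatter)), so among these compounds chain size alone does not reach the number of compound 1 at 20 nM, and an oxygen in the chain does not reach it either, as compound 3 goes against any such rule. Nothing among the available data explains why the propoxy chain stands apart from the other three.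

On these data alone, what remains open is how far the low number depends on the place of the oxygen and the length of the chain beyond it, which ethoxy and butoxy chains on the same core would address. As far as these compounds go, it is also open whether the branch in 1-methylbutyl matters, which a straight hexyl chain would test, and whether an amine could take the place of the ether oxygen.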